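The source may report more compounds than this note shows. Statements on the series, on what has been measured and on what is new or still open speak of the compounds shown alone.

Measured compounds:
compound 1 `O=C(Nc1ccc(-n2ccc3c(NC(=O)c4ccccc4)nccc32)cc1)Nc1cccc(C(F)(F)F)c1`: 7000 nM
compound 2 `O=C(Nc1ccc(-n2ccc3c(NC(=O)c4ccccc4)nccc32)cc1)Nc1cc(C(F)(F)F)cc(C(F)(F)F)c1`: 1800 nM
compound 3 `Nc1nccc2c1ccn2-c1ccc(NC(=O)Nc2cccc(C(F)(F)F)c2)cc1`: 5400 nM

In a functional assay on A-375 cells (Homo sapiens) for antiproliferative activity, read by MTT assay, with a stated time of 48 h, in the presence of a further agent that is not named here (on this read-out higher numbers stand for weaker inhibition and lower numbers for stronger inhibition), compound 1 gives 7000 nM, the highest of the three numbers. Compound 3 gives 5400 nM; the step of a 1.3-fold lower number from compound 1 to compound 3 (0.11 log units; within the scatter) is within the scatter, so the two are not to be ordered. Compound 2 gives 1800 nM, and the step of a 3.9-fold lower number from compound 1 to compound 2 (0.59 log units; beyond the scatter) is the only one beyond the scatter.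

Compound 4 `O=C(Nc1ccc(-n2ccc3c(NC(=O)c4ccccc4)nccc32)cc1)c1ccc(Cl)c(C(F)(F)F)c1` differs from compound 1 in one place: 4-chloro-3-(trifluoromethyl)phenyl in place of (3-(trifluoromethyl)phenyl)amino on a carbonyl carbon. Neither measured step is of this kind. The step from compound 1 to compound 2 alters the same aromatic ring but keeps the amino link to the carbonyl carbon; the step from compound 1 to compound 3 alters the benzoyl on the shared core and leaves the carbonyl side untouched. Among the compounds with values here, no measured step therefore bears directly on the change from compound 1 to compound 4. Within the data shown here, the only loose guide is that a further substituent on that ring went with the modest step of a 3.9-fold lower number from compound 1 to compound 2 (0.59 log units; beyond the scatter), while the loss of the amino link is untested. The expectation is wide and centred near compound 1.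

Compound 4 is expected to give 4000 nM, with a range of 1000 nM to 16000 nM. The expected step is a 1.8-fold lower number from compound 1 to compound 4 (0.24 log units; within the scatter), not confidently beyond the scatter.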

Compound 4, half-maximal inhibitory concentration: 16.4 nM
Estimate against measurement, compound 4: 240-fold (2.39 log units) above, outside the stated range (below it).
By their numbers in this assay, from the lowest: compound 4; then compound 2; then compounds 3 and 1 (each within the scatter of the next).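

In this assay, within the data shown here, the group on the carbonyl carbon carries far more weight than the earlier compounds suggested: the step is a 430-fold lower number from compound 1 to compound 4 (2.63 log units; beyond the scatter), set against a 3.9-fold lower number from compound 1 to compound 2 (0.59 log units; beyond the scatter) for a second trifluoromethyl on the ring and a 1.3-fold lower number from compound 1 to compound 3 (0.11 log units; within the scatter) for hydrogen in place of benzoyl, the last of these within the scatter. The change to the 4-chloro-3-(trifluoromethyl)phenyl group removes the amino link and adds a chlorine in a single step, so the size of this step cannot be divided between those two differences. Nothing at hand explains why the change has so large an effect on this read-out.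

The compounds shown do not separate the loss of the amino link from the gain of the chlorine, and a bromine or a methyl in place of that chlorine would test whether the chlorine itself matters. Also open, as far as these compounds go, is whether the benzoyl on the nitrogen still makes little difference once the 4-chloro-3-(trifluoromethyl)phenyl group is on the carbonyl carbon, as a free amine at that nitrogen in the compound 4 series would show.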